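One side group exchanged on compound 3

The source may report more compounds than this note shows. Statements on the series, on what has been measured and on what is new or still open speak of the compounds shown alone.

Compound 1 `CCCCNc1nc(N)c2nc(O)n(Cc3ccc(C)cc3)c2n1`: < 1000 ug/mL (a limit of the assay, not a number)
Compound 2 `CCCCNc1nc(N)c2[nH]c(=O)n(Cc3ccc(N4CCN(C)CC4)cc3)c2n1`: 108000 ug/mL
Compound 3 `CCCCNc1nc(N)c2[nH]c(=O)n(Cc3ccc(OCCCN(C)C)nc3)c2n1`: 288000 ug/mL

These three results come from a physicochemical assay for solubility, at pH 7.4; a higher number here means a more soluble compound, a lower number a less soluble compound. Compound 1 is reported only as a limit. Of the two true numbers, the higher belongs to compound 3, and its gap to compound 2, the nearest value, lies beyond the usual scatter.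

The next compound in the account is compound 4 `CCCCNc1nc(N)c2[nH]c(=O)n(Cc3ccc(N4CCC(N(C)C)C4)nc3)c2n1`, which has not yet been measured. It carries 3-(dimethylamino)pyrrolidin-1-yl in place of 3-(dimethylamino)propoxy on an aromatic carbon. The exchange sits next to the ring nitrogen and para to a large group, and the shared core stays as it is.

Among the compounds with values here, no two measured compounds differ in one place only, so the size of this step has to be judged indirectly. Within the data shown here, compound 2, the one measured compound with a non-aromatic ring on its aromatic ring, gives 108000 ug/mL. On that basis a slight fall is expected in this assay, probably no step beyond the scatter. The estimated change is a 1.4-fold lower number from compound 3 to compound 4 (0.16 log units; within the scatter). Compound 4 is expected to give an estimated 200000 ug/mL, within a range of 70000 ug/mL to 500000 ug/mL.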

Compound 4, solubility: 53000 ug/mL
Compound 4: middle estimate off by 3.8-fold (0.58 log units), on the high side; measured number below the stated range.
By their numbers in this assay, from the lowest: compound 4; then compound 2; then compound 3. At a limit, below all of these: compound 1.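

In this assay, within the data shown here, the step of a 5.4-fold lower number from compound 3 to compound 4 (0.74 log units; beyond the scatter) is the first one that can be read directly, and it shows that the number responds to a change at this position, on an aromatic carbon next to the ring nitrogen. The entering 3-(dimethylamino)pyrrolidin-1-yl and the leaving 3-(dimethylamino)propoxy have the same counts of hydrogen-bond donors and acceptors and no net charge, so those counts do not separate the two groups, yet the step still lies beyond the scatter. Nothing measured here gives a reason for this step.

The exchange replaces an open chain joined through oxygen with a ring joined through nitrogen, so the compounds shown cannot tell whether the step follows the ring, the linking atom or the extra heavy atom. An open 3-(dimethylamino)propylamino chain at the same position would separate the linking atom from the ring, and a piperidine ring carrying the same dimethylamino group would test whether the size of the ring matters.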